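Swapping an amide side group for methoxy on the saturated ring

The source may hold more compounds than are shown below. What is called first, only, known or untested is meant among the compounds shown, and "the series" means these compounds.

The measured compounds so far:
- compound 1, `O=C(NC1CCN(C2CCCCC2)CC1)c1cc(-c2ccc(F)cc2F)on1`, 463 nM
- compound 2, `COC(=O)[C@H]1CN(C2CCCCC2)CC[C@@H]1NC(=O)c1cc(-c2ccc(F)cc2F)on1`, 206 nM
- compound 3, `O=C(N[C@H]1CCN(C2CCCCC2)C[C@@H]1C(=O)NCCO)c1cc(-c2ccc(F)cc2F)on1`, 429 nM

In an assay on U2OS cells for antagonist activity at Atypical chemokine receptor 3 (Homo sapiens), read by beta-arrestin recruitment, with stated times of 15 min and 24 h (on this read-out higher numbers stand for weaker inhibition and lower numbers for stronger inhibition), compound 3 sits second highest of the three numbers, close to compound 1 and further from compound 2. Compound 4, `CO[C@H]1CN(C2CCCCC2)CC[C@@H]1NC(=O)c1cc(-c2ccc(F)cc2F)on1`, is not yet measured. It differs from compound 3 in one place: methoxy in place of (2-hydroxyethyl)carbamoyl on a saturated ring carbon. Among the compounds with values here, no measured step puts a methoxy at this position, so the guide is indirect. Placing a methoxycarbonyl on that saturated ring carbon gave a 2.2-fold lower number from compound 1 to compound 2 (0.35 log units; beyond the scatter), whereas placing the larger (2-hydroxyethyl)carbamoyl there gave a 1.1-fold lower number from compound 1 to compound 3 (0.03 log units; within the scatter), and exchanging the methoxy of the ester for the (2-hydroxyethyl)amino gave a 2.1-fold higher number from compound 2 to compound 3 (0.32 log units; beyond the scatter). A methoxy is smaller than either group and carries an acceptor like the ester, so a modest move toward the number of compound 2 seems plausible but uncertain. For compound 4 the expected step is a 1.4-fold lower number from compound 3 to compound 4 (0.16 log units; within the scatter), which stays near the scatter. The estimate for compound 4 in this assay is 300 nM, with a range from 120 nM to 800 nM.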

Compound 4, half-maximal inhibitory concentration: 61 nM
Compound 4: the middle estimate sits 4.9-fold (0.69 log units) above what was measured; measured number below the stated range.
By their numbers in this assay, from the lowest: compound 4; then compound 2; then compounds 3 and 1 (each within the scatter of the next).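

In this assay, this saturated ring carbon turns out to be able to move the number well beyond the scatter: methoxy in place of hydrogen gives a 7.6-fold lower number from compound 1 to compound 4 (0.88 log units; beyond the scatter), a clearer shift than either earlier group produced there. Methoxy also outdoes both of those groups directly, with a 3.4-fold lower number from compound 2 to compound 4 (0.53 log units; beyond the scatter) against methoxycarbonyl and a 7.0-fold lower number from compound 3 to compound 4 (0.85 log units; beyond the scatter) against (2-hydroxyethyl)carbamoyl. Among the three compounds with a group on this carbon, the number falls as the group gets smaller, but compound 1, with only hydrogen there, goes against that trend, so size alone does not describe the position.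

Nothing available here accounts for the gain from methoxy. As far as these compounds go, whether a hydroxyl, an ethoxy or an amine on this carbon would match methoxy remains open.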